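Extending the chain from compound 2 to compound 3

The source may report more compounds than this note shows. Statements on the series, on what has been measured and on what is new or still open speak of the compounds shown alone.

Compound 1 `CCCCCCCn1cc(COC[C@@H]2OC[C@H](N)[C@@H]2O)nn1` and compound 2 `CCCCCCCCn1cc(COC[C@@H]2OC[C@H](N)[C@@H]2O)nn1` share a core and differ only in the saturated chain carried on an aromatic nitrogen. In a functional assay on MGC-803 cells (Homo sapiens) for antiproliferative activity, read by MTT assay, with a stated time of 48 h (a higher number here means a weaker inhibitor, a lower number a stronger inhibitor), compound 1 gives > 128000 nM, which is a limit of the assay and not a number. Among the compounds with values here, compound 2 gives 70400 nM, the only true number so far, so it has no measured neighbour to be ranked against exactly.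

Compound 3 `CCCCCCCCCn1cc(COC[C@@H]2OC[C@H](N)[C@@H]2O)nn1` lengthens the same chain once more: methyl in place of hydrogen on a saturated chain carbon, eight bonds along the chain from an aromatic nitrogen. This is methyl in place of hydrogen on a saturated chain carbon, eight bonds along the chain from an aromatic nitrogen.

Within the data shown here, only one measured step bears on this change, the same replacement made seven bonds along the chain: an at least 1.8-fold lower number from compound 1 to compound 2 (0.25 log units; that floor lies within the scatter). That step gives a direction towards a lower number and only a floor for its size, so it is thin support. A modest further move the same way is therefore expected, and it may not clear the scatter. The expected change is a 1.9-fold lower number from compound 2 to compound 3 (0.27 log units; within the scatter). For compound 3 the estimated value is 38000 nM, with an expected range from 15000 nM to 90000 nM.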

Compound 3, half-maximal inhibitory concentration: 13800 nM
Beside the measured number, compound 3's estimate is 2.8-fold (0.44 log units) above it; measured number outside the range, below it.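

Methyl in place of hydrogen on a saturated chain carbon, eight bonds along the chain from an aromatic nitrogen, gives in this assay a 5.1-fold lower number from compound 2 to compound 3 (0.71 log units; beyond the scatter), and this is the first step on this chain that joins two true numbers and so has a definite size, one that stands clear of the scatter, whereas the earlier step seven bonds along offered only a floor inside it. Taken together, the two extensions give an at least 9.2-fold lower number from compound 1 to compound 3 (0.96 log units; beyond the scatter), so among the three compounds shown the chain position responds to added length, and nothing here goes against that direction. The value for compound 1 is a limit of the assay and not a number, and the whole span from compound 1 is therefore a floor and its true size stays unknown: the limit of > 128000 nM in this assay, at which 1 of the 3 values shown sits.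

The compounds shown leave open whether a longer chain would carry the same direction further or whether the trend would level off or turn back. They also leave open how this chain position would respond to a branched chain, or to a chain ending in an amine or a carboxylic acid in place of the terminal methyl.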